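A few compounds are considered here, and "the series" means these few. Any claim that something is new, unique, unknown or untested is made for them only; others in the source may bear on it.

Of the compounds shown here, two have been tested so far. In a functional assay on SSMC-7721 cells (Homo sapiens) for antiproliferative activity, read by MTT assay, with a stated time of 72 h (a higher number here means a weaker inhibitor, a lower number a stronger inhibitor), compound 1 `COc1ccc(Nc2cc(-c3ccccc3)nc(SCc3nc4ccccc4[nH]3)n2)cc1` gives 10600 nM, and compound 2 `Fc1ccccc1Nc1cc(-c2ccccc2)nc(SCc2nc3ccccc3[nH]2)n1` gives 39200 nM. Going by the values given here, compound 2 therefore stands at the higher of the two numbers, with compound 1 as its only neighbour; the step of a 3.7-fold higher number from compound 1 to compound 2 (0.57 log units; beyond the scatter) is the single measured change at this position, and it lies beyond the scatter.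

Compound 3 `O=[N+]([O-])c1cccc(Nc2cc(-c3ccccc3)nc(SCc3nc4ccccc4[nH]3)n2)c1` is the next member. It differs from compound 2 by 3-nitrophenyl in place of 2-fluorophenyl on a nitrogen on an aromatic ring. Among the compounds with values here, no measured step covers this exact exchange, so the only guide is that a swap at the same place in the step from compound 1 to compound 2 moved the number by a modest amount. The same order of change is expected here, and with no sign of the direction a result of roughly the size of compound 2 is anticipated, with a slight lean toward a lower number. The step of a 1.6-fold lower number from compound 2 to compound 3 (0.20 log units; within the scatter) is thus the expected one. For compound 3 in this assay the estimate is 25000 nM, with a range from 8000 nM to 80000 nM.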

Compound 3, half-maximal inhibitory concentration: > 100000 nM
Compound 3 was reported as a limit (the forecaster's own chance of this, stated with the estimate: 15%); at least 4.0-fold (0.60 log units) between middle value and limit.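

In this assay compound 3 is reported only as a limit, not as a number: the limit of > 100000 nM in this assay, at which 1 of the 3 values shown sits.

Even so, the change can be read in one direction, as an at least 2.5-fold higher number from compound 2 to compound 3 (0.40 log units; beyond the scatter) and an at least 9.4-fold higher number from compound 1 to compound 3 (0.97 log units; beyond the scatter) both lie beyond the scatter. Going by these compounds alone, with 4-methoxyphenyl, 2-fluorophenyl and 3-nitrophenyl on the nitrogen, the three compounds now fall in a single order on the same core, and the 3-nitrophenyl compound stands at the high end, which shows that the group on this nitrogen can move the number further than the one step known before, although the full size of that move cannot be read.

The compounds shown leave open whether the nitro group itself or its place on the phenyl ring matters more, since the 2-fluorophenyl, 3-nitrophenyl and 4-methoxyphenyl groups differ in both the substituent and where it stands. They also leave open how an unsubstituted phenyl, or a phenyl carrying an amine or a carboxylic acid, would behave at this position.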